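The compounds below may be only part of what the source reports. "The series", "measured", "known", "first", "only" and "open" are said of these compounds alone.

Measured compounds:
compound 1 `C[C@H](C#Cc1cccc(C(=O)NCCC(c2ccc(F)cc2)c2ccc(C(F)(F)F)cc2)c1)N(O)C(N)=O` — 220 nM
compound 2 `C[C@H](C#Cc1cccc(C(=O)NCCC(c2ccc(F)cc2)c2ccc(OC(F)(F)F)cc2)c1)N(O)C(N)=O` — 260 nM
compound 3 `CCC(C#Cc1cccc(C(=O)NCc2ccccc2C(F)(F)F)c1)N(O)C(N)=O` — 500 nM

In an assay for inhibition of Polyunsaturated fatty acid 5-lipoxygenase (Homo sapiens), read by HPLC, with stated times of 15 min and 10 min (a higher number here means a weaker inhibitor, a lower number a stronger inhibitor), compound 2 gives the second highest of the three numbers, yet both its neighbours sit within the scatter: compound 1 is nearest, compound 3 furthest, and neither gap is beyond it. Compound 4 `C[C@H](C#Cc1cccc(C(=O)NCCC(c2ccc(F)cc2)c2ccc(F)cc2)c1)N(O)C(N)=O` differs from compound 2 by fluoro in place of trifluoromethoxy on an aromatic carbon. Going by the values given here, the one measured step that bears on this position is a 1.2-fold higher number from compound 1 to compound 2 (0.07 log units; within the scatter), which is within the scatter; no measured pair shows a fluoro at this place, so the size of the present change rests on that single step alone. The expected step of a 1.0-fold lower number from compound 2 to compound 4 (0.02 log units; within the scatter) is therefore within the scatter, in no clear direction. For compound 4 the estimate in this assay is 250 nM, with a range from 120 nM to 550 nM.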

Compound 4, half-maximal inhibitory concentration in the Polyunsaturated fatty acid 5-lipoxygenase assay: 110 nM
The estimate for compound 4 lay 2.3-fold (0.36 log units) above the measured number, outside the stated range (below it).
By their numbers in the Polyunsaturated fatty acid 5-lipoxygenase assay, from the lowest: compounds 4, 1, 2 and 3 (each within the scatter of the next, the first and the last beyond it).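

In the Polyunsaturated fatty acid 5-lipoxygenase assay, this position proves sensitive to the group it carries, which the pair of compound 1 and compound 2 did not show: fluoro in place of trifluoromethoxy gives a 2.4-fold lower number from compound 2 to compound 4 (0.37 log units; beyond the scatter). Fluoro in place of trifluoromethyl gives a 2.0-fold lower number from compound 1 to compound 4 (0.30 log units; within the scatter), so only the change from trifluoromethoxy clears the scatter. In a physicochemical assay for solubility, at pH 7.4 (on this read-out lower numbers stand for lower solubility and higher numbers for higher solubility), compound 2 gives 10000 nM and compound 4 gives 3000 nM, so the change from trifluoromethoxy to fluoro also comes with lower solubility: the measured solubility of compound 2, 10000 nM, and of compound 4, 3000 nM, a 3.3-fold lower number (0.52 log units; beyond the scatter)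

Still open, from the compounds shown here alone, is whether an amine or a carboxylic acid on this aromatic carbon would match compound 4 in the Polyunsaturated fatty acid 5-lipoxygenase assay without that loss of solubility.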